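Cyclic Urea Replaces Thiazolylamine on the Shared Core

The source may hold more compounds than are shown below. What is called first, only, known or untested is meant among the compounds shown, and "the series" means these compounds.

Measured so far:
compound 1, `CC(C)NC(=O)CC(c1ccc(-c2ccc3cccc(F)c3c2)[nH]c1=O)C(C)C`, 5.8 nM
compound 2, `CC(C)C(Nc1nccs1)c1ccc(-c2ccc3cccc(F)c3c2)[nH]c1=O`, 9.4 nM

In an assay on CHO cells for displacement of a labelled ligand from prostaglandin E2 receptor EP3 subtype (Homo sapiens), read by radioligand binding (on this read-out lower numbers stand for stronger inhibition and higher numbers for weaker inhibition), compound 1 gives 5.8 nM, and compound 2 gives 9.4 nM. For the measured compounds named here, compound 2 shows the higher of the two numbers, yet the only measured step, a 1.6-fold higher number from compound 1 to compound 2 (0.21 log units; within the scatter), lies within the scatter, so the two compounds cannot be told apart on this read-out.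

Compound 3, `CC(C)C(c1ccc(-c2ccc3cccc(F)c3c2)[nH]c1=O)N1CCNC1=O`, has not yet been measured in this assay. It differs from compound 2 in one place: 2-oxoimidazolidin-1-yl in place of (1,3-thiazol-2-yl)amino on a saturated chain carbon bound to an aromatic carbon and a saturated chain carbon.

Going by the values given here, no measured step exchanges one nitrogen-linked group for another on this carbon; the step of a 1.6-fold higher number from compound 1 to compound 2 (0.21 log units; within the scatter) is the nearest guide, and it swapped a quite different side group for the thiazolylamine without moving the number beyond the scatter. That step therefore gives no reason to expect a large shift in either direction, but its support for this new change is indirect, so the range stays wide. The estimated value for compound 3 is 12 nM (range 4 nM to 40 nM), which would be a step of a 1.3-fold higher number from compound 2 to compound 3 (0.11 log units; within the scatter), expected to fall within the scatter.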

Compound 3, inhibition constant: 9.1 nM
The estimate for compound 3 lay 1.3-fold (0.12 log units) above the measured number; measured number inside the range.
By their numbers in this assay, from the lowest: compounds 1, 3 and 2 (each within the scatter of the next).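

Replacing the (1,3-thiazol-2-yl)amino group with 2-oxoimidazolidin-1-yl gave a 1.0-fold lower number from compound 2 to compound 3 (0.01 log units; within the scatter) in this assay, so this direct exchange of one nitrogen-linked group for another on the saturated chain carbon leaves the two compounds indistinguishable, even though a five-membered aromatic ring with sulfur gives way to a five-membered non-aromatic ring with a carbonyl oxygen. Set against the (isopropylcarbamoyl)methyl group, the same ring gives a 1.6-fold higher number from compound 1 to compound 3 (0.20 log units; within the scatter), so all three compounds now lie within the scatter of one another, and this position has taken three differently built groups without a step beyond the scatter in this assay. Nothing measured here explains why these groups cannot be told apart.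

What these three compounds leave open is whether the position stays this flat for groups of a quite different kind, such as a carboxylic acid, a primary amine or a longer chain in place of the ring. They also leave open whether the isopropyl group on the neighbouring saturated chain carbon matters to the number, since all three compounds carry it.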